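A few compounds are considered here, and "the series" means these few. Any claim that something is new, unique, unknown or untested is made for them only; others in the source may bear on it.

Of the compounds shown here, two have been tested in an assay on isolated protein for inhibition of ubiquitin carboxyl-terminal hydrolase 7 (Homo sapiens), with stated times of 30 min and 2 h; on this read-out lower numbers stand for stronger inhibition and higher numbers for weaker inhibition. Compound 1, `CC(C)NCc1ccc(-c2c3ncn(CC4(O)CCN(Cc5ccc(-c6ccco6)cc5Cl)CC4)c(=O)c3nn2C)cc1`, gives 29.1 nM in this assay. Compound 2, `Cn1nc2c(=O)n(CC3(O)CCN(Cc4ccc(C5=CCCC5)cc4Cl)CC3)cnc2c1-c1ccc(CN)cc1`, gives 76.9 nM in this assay, the higher of the two numbers, and the gap to compound 1 lies beyond the usual scatter of repeated runs.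

Compound 3, `Cn1nc2c(=O)n(CC3(O)CCN(Cc4ccc(-c5ccco5)cc4Cl)CC3)cnc2c1-c1ccc(CN)cc1`, keeps the core and the aminomethyl-bearing ring of compound 2 and differs from it in one place: furan-2-yl in place of cyclopent-1-en-1-yl on an aromatic carbon. Within the data shown here, the same furan-2-yl group is present in compound 1, which gives the lower of the two known numbers, but compound 1 also differs from compound 2 elsewhere, so the two compounds do not isolate this single change.

On that basis, compound 3 is expected to show a modest improvement, a step of a 1.5-fold lower number from compound 2 to compound 3 (0.19 log units; within the scatter) in this assay. Compound 3 is estimated at 50 nM, with a likely range from 20 nM to 150 nM.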

Compound 3, half-maximal inhibitory concentration: 18.1 nM
The estimate for compound 3 lay 2.8-fold (0.44 log units) above the measured number, and the stated range ends above it.
By their numbers in this assay, from the lowest: compounds 3 and 1 (each within the scatter of the next); then compound 2.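

In this assay, furan-2-yl in place of cyclopent-1-en-1-yl, on the aromatic carbon para to a large group, gives a 4.2-fold lower number from compound 2 to compound 3 (0.63 log units; beyond the scatter), so this single change is now seen on its own and is larger than the scatter. Hydrogen in place of isopropyl on an amine nitrogen gives a 1.6-fold lower number from compound 1 to compound 3 (0.21 log units; within the scatter), which lies within the scatter, so with furan-2-yl present these two amines cannot be told apart here. Nothing available explains why furan-2-yl gives the lower number than cyclopent-1-en-1-yl.

The compounds shown leave open how a thiophene or a phenyl ring would compare with furan-2-yl at this position. They also leave open whether the furan-2-yl step keeps its size when the amine nitrogen carries isopropyl.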